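A few compounds are considered here, and "the series" means these few. Any claim that something is new, unique, unknown or untested is made for them only; others in the source may bear on it.

Compound 1 `CC(C)N(C(=S)SCc1oc2ccccc2c(=O)c1Cl)C(C)C` in a functional assay on MCF7 cells (Homo sapiens) for antiproliferative activity, read by MTT assay, with a stated time of 72 h (on this read-out lower numbers stand for stronger inhibition and higher numbers for weaker inhibition), is reported only as a limit, > 40000 nM. Compound 2 `O=c1c(Cl)c(CSC(=S)N2CCCC2)oc2ccccc12` in this assay gives 2300 nM.

Compound 2 therefore provides the only number shown, the other value being a limit (the limit of > 40000 nM in this assay, at which 1 of the 2 values shown sits). For the measured compounds named here, the step of an at least 17-fold lower number from compound 1 to compound 2 (1.24 log units; beyond the scatter) was the only measured step, and it replaced a different group. Compound 3 `O=c1c(Cl)c(CSC(=S)N2CCOCC2)oc2ccccc12` carries morpholin-4-yl in place of pyrrolidin-1-yl on a thiocarbonyl carbon. Going by the values given here, no measured step involves morpholin-4-yl, so the expected change is small, within or near the scatter, and the estimated step is a 1.7-fold higher number from compound 2 to compound 3 (0.24 log units; within the scatter). Compound 3 is expected to give about 4000 nM in this assay, with a range from 1500 nM to 15000 nM.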

Compound 3, half-maximal inhibitory concentration: 11100 nM
Estimate against measurement, compound 3: 2.8-fold (0.44 log units) below, and the stated range covers the measured number.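

In this assay, morpholin-4-yl in place of pyrrolidin-1-yl on the thiocarbonyl carbon gives a 4.8-fold higher number from compound 2 to compound 3 (0.68 log units; beyond the scatter) and shows that this place separates two ring amines, not only a ring amine from an open one. Morpholin-4-yl still keeps its lead over diisopropylamino, with an at least 3.6-fold lower number from compound 1 to compound 3 (0.55 log units; beyond the scatter) as the step, so pyrrolidin-1-yl ranks first of the three groups. That last step is open-ended: the limit of > 40000 nM in this assay, at which 1 of the 3 values shown sits. The compounds shown cannot separate ring size from the ring oxygen. A piperidin-1-yl group, with the larger ring but no oxygen, would bear on that question.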